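Chloro for Bromo and Its Effect on Cell Growth Inhibition

A few compounds are considered here, and "the series" means these few. Any claim that something is new, unique, unknown or untested is made for them only; others in the source may bear on it.

Of the compounds shown here, three have been tested in an ADME assay on 184B5 cells (Homo sapiens) for cytotoxicity, read by sulforhodamine B assay, with a stated time of 48 h; on this read-out higher numbers stand for weaker inhibition of growth and lower numbers for stronger inhibition of growth. Compound 1 `CCN(CC)CN1C(=O)/C(=N\c2nc3ccc(C)cc3s2)c2c(Br)cccc21` carries a bromo group and gives 34300 nM in this assay. Compound 2 `CCN(CC)CN1C(=O)C(=O)c2c(Br)cccc21` also carries a bromo group but on a different core; the difference between the two cores is not broken down here. In this assay compound 2 gives 172000 nM, a higher number than compound 1, and the gap lies beyond the scatter. Compound 3 `CCN(CC)CN1C(=O)C(=O)c2c(Cl)cccc21` shares the core of compound 2. In this assay compound 3 gives 22500 nM, a value that sits within the scatter of compound 1.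

Within the data shown here, the one structural change measured so far is chloro in place of bromo on an aromatic carbon, and it produced a 7.6-fold lower number from compound 2 to compound 3 (0.88 log units; beyond the scatter). Compound 4 `CCN(CC)CN1C(=O)/C(=N\c2nc3ccc(C)cc3s2)c2c(Cl)cccc21` has not yet been measured. Among the measured compounds shown here, it is related to compound 1 by chloro in place of bromo on an aromatic carbon, which is the same change, made at the same place, as the one separating compound 2 from compound 3.

For the measured compounds named here, with only one precedent, and that on a different core, the expectation for compound 4 in this assay is a step of a 3.8-fold lower number from compound 1 to compound 4 (0.58 log units; beyond the scatter) from compound 1, somewhat smaller than the earlier one to allow for the change of core. Compound 4 is therefore expected to give about 9000 nM, because the same change gave a 7.6-fold lower number from compound 2 to compound 3 (0.88 log units; beyond the scatter). A value for compound 4 between 3000 nM and 30000 nM is estimated as likely.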

Compound 4, concentration for 50% growth inhibition: 87800 nM
Beside the measured number, compound 4's estimate is 9.8-fold (0.99 log units) below it; the whole stated range lies below it.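

In this assay, chloro in place of bromo on an aromatic carbon gave a 2.6-fold higher number from compound 1 to compound 4 (0.41 log units; beyond the scatter), so the lower number seen on the other core did not carry over to this one. On these two cores, the same swap at the same place moved the number in opposite directions, which means that the result of this change depends on the core it is made on, and a step measured on one core is a poor guide to the other: the same change on two cores in this assay, a 7.6-fold lower number (0.88 log units; beyond the scatter) from compound 2 to compound 3 and a 2.6-fold higher number (0.41 log units; beyond the scatter) from compound 1 to compound 4, 20-fold (1.29 log units) apart, beyond the scatter of two such steps. Among these compounds, this rests on only two matched pairs, however, so it shows neither why the two cores part ways nor how the change would behave on any further core.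

The compounds shown leave open how fluoro, iodo or methoxy on that same aromatic carbon would compare with chloro and bromo on each of the two cores, which would show whether the opposite steps are peculiar to this one swap. They also leave open whether the steps would keep their opposite directions if a morpholine took the place of the diethylamino group.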